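Ethyl to cyclopentyl on the carbonyl of compound 2

This account rests on a few compounds, and the source may have more. Where it says the series, first, only, none or still open, it means among the compounds named here.

Two different cores appear here. Compound 1 `CC(=O)N1CCC(C(=O)N2CCC(N3CCN(C(=O)c4cc(-c5ccc(C)cc5)nc(-c5ccc6[nH]c(C)c(C)c6c5)c4)CC3)CC2)CC1` has been tested in a functional assay on HepG2 cells (Homo sapiens) for inhibition, read by scintillation counting, with a stated time of 2 h (on this read-out lower numbers stand for stronger inhibition and higher numbers for weaker inhibition), where compound 1 gives 294 nM. Compound 2 `CCNC(=O)Nc1sc2ccccc2c1C(=O)N1CCN(C2CCN(C(=O)CC)CC2)CC1` belongs to another core; in this assay compound 2 has "not determined" (no result reported), so no number exists for it and its standing cannot be placed against compound 1. Compound 3 `CCNC(=O)Nc1sc2ccccc2c1C(=O)N1CCN(C2CCN(C(=O)C3CCCC3)CC2)CC1` is built from compound 2 with a single change: cyclopentyl in place of ethyl on a carbonyl carbon. Among the compounds with values here, no measured pair shows a step of this kind, and compound 2 itself has no value, so the size of the step in this assay cannot be read from what is known; a change no larger than the usual scatter, in either direction, is the plainest expectation. Compound 3 is therefore estimated to give 800 nM, with a wide range from 100 nM to 6000 nM. This expectation rests only on the level compound 1 shows at 294 nM.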

Compound 3, half-maximal inhibitory concentration: 309 nM
Compound 3: the middle estimate sits 2.6-fold (0.41 log units) above what was measured; the range from low to high includes it.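

Compound 3 gives 309 nM but no step can be read from it, since compound 2 has no number to set against it and compound 1 has a different core. As far as these compounds go, whether replacing ethyl with cyclopentyl on the carbonyl changes inhibition stays open. No supporting data bear on this result.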